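This account rests on a few compounds, and the source may have more. Where it says the series, first, only, none or still open, it means among the compounds named here.

In an ADME assay on Huh-7 cells (Homo sapiens) for cytotoxicity, read by MTT assay, with a stated time of 48 h (on this read-out higher numbers stand for lower toxicity in this test and lower numbers for higher toxicity in this test), compound 2, whose structure is `CN(C)CCCCOC(=O)Nc1ccc(Cn2nc(-c3cncnc3)c3ccccc3c2=O)cc1`, gives 65300 nM, the highest of the two numbers obtained so far. For the measured compounds named here, compound 1, `CC(c1ccc(N(CCCCN(C)C)C(=O)O)cc1)n1nc(-c2ccc(F)cc2)c2ccccc2c1=O`, gives 15200 nM in this assay; no step between these two is worked out here, and compound 2 simply shows the larger value of the pair.

Compound 3 is `CN(C)CCCCOC(=O)Nc1ccc(Cn2nc(-c3ccccc3C#N)c3ccccc3c2=O)cc1`. It differs from compound 2 in one place: 2-cyanophenyl in place of pyrimidin-5-yl on an aromatic carbon.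

Going by the values given here, no step between measured compounds is available to guide this change. The estimate for compound 3 in this assay is therefore taken close to compound 2, with an expected step of a 1.6-fold lower number from compound 2 to compound 3 (0.21 log units; within the scatter) that is modest and downward, not clearly beyond the scatter. Compound 3 is expected to give about 40000 nM in this assay, within a range from 12000 nM to 100000 nM.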

Compound 3, half-maximal cytotoxic concentration: 90700 nM
Beside the measured number, compound 3's estimate is 2.3-fold (0.36 log units) below it; the measured number falls inside the stated range.
By their numbers in this assay, from the lowest: compound 1; then compounds 2 and 3 (each within the scatter of the next).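

In this assay, for the compounds shown here, the exchange of pyrimidin-5-yl for 2-cyanophenyl on this aromatic carbon, next to the ring nitrogen, gives a 1.4-fold higher number from compound 2 to compound 3 (0.14 log units; within the scatter) and provides the first one-place comparison. At this position, a six-membered aromatic ring with two hetero atoms and a carbon-only ring bearing a nitrile therefore give values that cannot be told apart in this test, even though the entering group is larger by its heavy-atom count. Nothing available bears on why the two groups read alike.

As far as these compounds go, whether a simple phenyl, an amine or a carboxylic acid at this position would also stay within the scatter of compound 2 remains open. Also open, from the compounds shown here alone, is how the read-out would respond to a longer chain in place of the one ending in dimethylamino.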